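Inverting the Ring Hydroxyl Stereocentre of Compound 3

The compounds below may be only part of what the source reports. "The series", "measured", "known", "first", "only" and "open" are said of these compounds alone.

Compound 1 `N#Cc1cccc(-c2ccc(CN(CCN3CCCC3)C(=O)Nc3cc(Cl)cc(Cl)c3)cc2)c1` gives 151 nM in a functional assay for antagonist activity at melanin-concentrating hormone receptor 1 (Homo sapiens); a lower number here means a stronger inhibitor, a higher number a weaker inhibitor.
Compound 2 `N#Cc1cccc(-c2ccc(CN(CC(=O)Nc3cc(Cl)cc(Cl)c3)C(=O)CN3CCCC3)cc2)c1` gives 35 nM in this assay.
Compound 3 `N#Cc1cccc(-c2ccc(CN(CC(=O)Nc3cc(Cl)cc(Cl)c3)C(=O)CN3CC[C@@H](O)C3)cc2)c1` gives 61 nM in this assay.

Among these three numbers, compound 3 holds the second highest. Its nearest neighbour is compound 2: the step of a 1.7-fold higher number from compound 2 to compound 3 (0.24 log units; within the scatter) stays inside the usual scatter of repeated measurements, so the two cannot be ranked against each other. The furthest is compound 1, whose number lies beyond the scatter above that of compound 3, and for that pair only the two values themselves can be compared.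

Compound 4 `N#Cc1cccc(-c2ccc(CN(CC(=O)Nc3cc(Cl)cc(Cl)c3)C(=O)CN3CC[C@H](O)C3)cc2)c1` is the next step. Compared with compound 3, (the two compounds have the same atoms and bonds and differ only in configuration as drawn: 1 of 1 stereo elements differ; a stereocentre at a saturated ring carbon is drawn R in compound 3 and S in compound 4). Nothing else moves.

For the measured compounds named here, no measured pair shows what happens when only the configuration of this stereocentre changes. Going by the values given here, the single measured step, a 1.7-fold higher number from compound 2 to compound 3 (0.24 log units; within the scatter), concerns introducing the hydroxy group, not its orientation, and it stayed within the scatter. There is thus no ground for expecting a shift beyond the scatter in this assay in either direction. The expected step is a 1.0-fold lower number from compound 3 to compound 4 (0.01 log units; within the scatter), which amounts to no change beyond the scatter. Compound 4 is therefore estimated at 60 nM, with a range from 22 nM to 160 nM.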

Compound 4, inhibition constant: 27 nM
Compound 4: middle estimate off by 2.2-fold (0.35 log units), on the high side; the range from low to high includes it.
By their numbers in this assay, from the lowest: compounds 4, 2 and 3 (each within the scatter of the next, the first and the last beyond it); then compound 1.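

For the compounds shown here, the orientation of the hydroxy group at this saturated ring carbon matters in this assay, which the earlier compounds could not show, since their one step concerned only adding the group. Inverting the stereocentre from drawn R to drawn S gives a 2.3-fold lower number from compound 3 to compound 4 (0.35 log units; beyond the scatter), a modest shift that can be assigned to the stereocentre alone because of one structural fact: the fact that compounds 3 and 4 differ only in the configuration as drawn. Set against the ring without the hydroxy group, neither form separates from compound 2, with a 1.7-fold higher number from compound 2 to compound 3 (0.24 log units; within the scatter) and a 1.3-fold lower number from compound 2 to compound 4 (0.11 log units; within the scatter), so the position accepts a hydroxy group in either configuration, and only the two hydroxy forms can be told apart from each other.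

The compounds shown leave open whether the preference for the drawn S form belongs to the hydroxy group or would also appear with another group at this ring carbon, such as a methoxy group, an amine or a carboxylic acid. They also leave open whether the same preference would hold on the chain of compound 1, which carries a urea in place of the two amide carbonyl groups of compound 4.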